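Swapping Fluoro for Cyano on a Pyrazole Core

This account rests on a few compounds, and the source may have more. Where it says the series, first, only, none or still open, it means among the compounds named here.

Compound 1 `O=C(O)/C=C/c1ccc(/C(=C(\c2ccc(F)cc2Cl)C2CCC2)c2ccc(-c3cncs3)cc2)cc1` and compound 2 `N#Cc1ccc(/C(=C(\c2ccc(/C=C/C(=O)O)cc2)c2ccc(-c3cncs3)cc2)C2CCC2)c(Cl)c1` share one core, while compound 3 `O=C(O)/C=C/c1ccc(/C(=C(\c2ccc(F)cc2Cl)C2CCC2)c2ccc(-c3cn[nH]c3)cc2)cc1` and compound 4 `N#Cc1ccc(/C(=C(\c2ccc(/C=C/C(=O)O)cc2)c2ccc(-c3cn[nH]c3)cc2)C2CCC2)c(Cl)c1` share another. In a functional assay on MCF7 cells (Homo sapiens) for antiproliferative activity, read by CellTiter-Glo, with a stated time of 5 days (on this read-out lower numbers stand for stronger inhibition and higher numbers for weaker inhibition), compound 1 gives 4.2 nM, compound 2 gives 2.9 nM, and compound 3 gives 2.9 nM. The two cores differ in one way, (1H-pyrazol-4-yl in place of 1,3-thiazol-5-yl on an aromatic carbon), and this change moved the number a 1.4-fold lower number from compound 1 to compound 3 (0.16 log units; within the scatter). The change from compound 1 to compound 2 is cyano in place of fluoro on an aromatic carbon, and it gave a 1.4-fold lower number from compound 1 to compound 2 (0.16 log units; within the scatter). The same change, (cyano in place of fluoro on an aromatic carbon), is made from compound 3 to compound 4; it occurs twice among these compounds, and the place in which it sits reads the same in both cases. Because the earlier instance gave a 1.4-fold lower number from compound 1 to compound 2 (0.16 log units; within the scatter), the step from compound 3 to compound 4 in this assay is expected to be about a 1.3-fold lower number from compound 3 to compound 4 (0.12 log units; within the scatter), resting on that single earlier step and on the value of compound 3, 2.9 nM. On that basis compound 4 is estimated at 2.2 nM, with a range from 1 nM to 5 nM.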

Compound 4, half-maximal inhibitory concentration: 2.2 nM
The estimate for compound 4 equals the measured number at the digits printed; the measured number falls inside the stated range.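

In this assay, cyano in place of fluoro gave a 1.3-fold lower number from compound 3 to compound 4 (0.12 log units; within the scatter), and set beside its earlier instance the change carried from one core to the other with no gap that can be told from scatter: the same change on two cores in this assay, a 1.4-fold lower number (0.16 log units; within the scatter) from compound 1 to compound 2 and a 1.3-fold lower number (0.12 log units; within the scatter) from compound 3 to compound 4, 1.1-fold (0.04 log units) apart, within the scatter of two such steps. The other change, 1H-pyrazol-4-yl in place of 1,3-thiazol-5-yl, gave a 1.3-fold lower number from compound 2 to compound 4 (0.12 log units; within the scatter), and it too reads alike on both cores: the same change on two cores in this assay, a 1.4-fold lower number (0.16 log units; within the scatter) from compound 1 to compound 3 and a 1.3-fold lower number (0.12 log units; within the scatter) from compound 2 to compound 4, 1.1-fold (0.04 log units) apart, within the scatter of two such steps. For the compounds shown here, all these steps are small and within the scatter, so the agreement shows only that neither change moved the number measurably on these two cores, not that a larger effect would carry over in the same way.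

The compounds shown leave open whether another group in that place, such as an amine or a methoxy group, would give a step beyond the scatter. Also open, on these data alone, is whether either change would carry over on a third core, or read the same outside this assay.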